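The compounds below may be only part of what the source reports. "The series", "measured", "known", "first", "only" and "open" are said of these compounds alone.

Measured compounds:
compound 1 `Cc1ccc2c(=O)c(CSC(=S)N3CCCCC3)coc2c1`: 1700 nM
compound 2 `O=c1c(SC(=S)N2CCCC2)coc2ccc(Cl)cc12`: 24000 nM
compound 3 `O=c1cc(CSC(=S)N2CCCCC2)oc2cc(Cl)ccc12`: 3000 nM

All three numbers come from a functional assay on MDA-MB-435S cells (Homo sapiens) for antiproliferative activity, read by MTT assay, with a stated time of 72 h; on this read-out higher numbers stand for weaker inhibition and lower numbers for stronger inhibition. Among them compound 3 stands second highest. Compound 1 is its nearest neighbour, and the gap between compound 1 and compound 3 lies within the scatter, so no order between the two can be read. Compound 2 is the furthest, its number lying beyond the scatter above that of compound 3.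

Compound 4 `O=c1cc(CSC(=S)N2CCCCC2)oc2ccccc12` has not been measured. It differs from compound 3 in one place: hydrogen in place of chloro on an aromatic carbon. Among the measured compounds shown here, no measured pair in this set carries the same change, so the numbers at hand give neither a direction nor a size for it. The expectation rests on compound 3 alone, whose number in this assay is 3000 nM. The step expected is a 1.3-fold higher number from compound 3 to compound 4 (0.12 log units; within the scatter), which is small and not beyond the scatter, with the wider range reflecting the missing precedent. Compound 4 is expected to give 4000 nM in this assay, within a range of 1500 nM to 12000 nM.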

Compound 4, half-maximal inhibitory concentration: > 25000 nM
Compound 4 was reported as a limit (the forecaster's own chance of this, stated with the estimate: 5%); middle value at least 6.2-fold (0.79 log units) away from the limit.
By their numbers in this assay, from the lowest: compounds 1 and 3 (each within the scatter of the next); then compound 2. At a limit, above all of these: compound 4.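

Among the compounds shown here, this is the first single change that can be read, and it shows that the chloro on this aromatic carbon, meta to a fused ring and para to a fused ring, matters: in this assay, hydrogen in its place gives an at least 8.3-fold higher number from compound 3 to compound 4 (0.92 log units; beyond the scatter). Compound 4 is reported as a limit of the assay, > 25000 nM. The true size of the loss therefore stays unknown, and the step gives only its lower bound: the limit of > 25000 nM in this assay, at which 1 of the 4 values shown sits.

Going by these compounds, whether the inhibition depends on chloro itself, or would also hold with another group on this carbon such as fluoro, methyl or methoxy, remains open. Also open, on these data alone, is whether swapping chloro for hydrogen would cost as much on the core of compound 1 or the core of compound 2.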